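The compounds below may be only part of what the source reports. "The series", "measured", "known", "first", "only" and "open" are said of these compounds alone.

Measured compounds:
Compound 1 `Cn1c(=O)n(C2CCN(CCCn3nc(-c4ccc(Cl)c(Cl)c4)c4c3CCN(S(C)(=O)=O)C4)CC2)c2ccccc21`: 10 nM
Compound 2 `CS(=O)(=O)N1CCc2c(c(-c3ccc(Br)cc3)nn2CC(O)CN2CCC(c3c[nH]c4ccc(Cl)cc34)CC2)C1`: 54 nM

In an assay on isolated protein for inhibition of cathepsin S (Homo sapiens) (on this read-out lower numbers stand for stronger inhibition and higher numbers for weaker inhibition), compound 2 gives 54 nM, the higher of the two numbers; compound 1 gives 10 nM, a lower number that lies beyond the scatter. Compound 3 `CS(=O)(=O)N1CCc2c(c(-c3ccc(Br)cc3)nn2CC(O)CN2CCC(c3c[nH]c4ncccc34)CC2)C1` is not yet measured. It differs from compound 2 in one place: a group of 9 heavy atoms (7 carbon, 2 nitrogen; one five-membered aromatic ring with 1 hetero atom, one six-membered aromatic ring with 1 hetero atom) in place of a group of 10 heavy atoms (8 carbon, 1 nitrogen, 1 chlorine; one five-membered aromatic ring with 1 hetero atom, one six-membered aromatic ring of carbon only), on a saturated ring carbon. Within the data shown here, no measured pair shows this change, so no step from the data can be quoted for it. A moderate step toward a higher number is expected, from compound 2 to compound 3 a 2.8-fold higher number from compound 2 to compound 3 (0.44 log units; beyond the scatter) in this assay. Compound 3 is thus estimated at 150 nM, within 50 nM to 450 nM.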

Compound 3, half-maximal inhibitory concentration: 195 nM
Beside the measured number, compound 3's estimate is 1.3-fold (0.11 log units) below it, and the stated range covers the measured number.
By their numbers in this assay, from the lowest: compound 1; then compound 2; then compound 3.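

In this assay, the 5-chloro-1H-indol-3-yl group on the saturated ring carbon gives way to a group with a hetero atom in its six-membered aromatic ring and no chlorine, and this brings a 3.6-fold higher number from compound 2 to compound 3 (0.56 log units; beyond the scatter). The position therefore responds to a change within this bicyclic group, even though the hydrogen-bond donor count stays the same. Nothing available here explains the step. The change alters two features at once, so the shares of the chlorine and the ring nitrogen stay unresolved. The unsubstituted 1H-indol-3-yl group would separate them.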